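Methoxy addition on the pyridine of compound 1

The compounds below may be only part of what the source reports. "The series", "measured", "known", "first", "only" and "open" are said of these compounds alone.

Of the compounds shown here, three sharing the bicyclic amine core have been measured in an in vitro assay on SH-EP1 cells for displacement of a labelled ligand from Neuronal acetylcholine receptor; alpha4/beta2 (Homo sapiens); a higher number here means a weaker inhibitor, a lower number a stronger inhibitor. Compound 1 `Clc1ccc(C2=CC3CNCC(C2)C3)cn1` gives 0.4 nM. Compound 3 `C1=C(c2cncc(Oc3ccccc3)c2)CC2CNCC1C2` gives 0.7 nM, and compound 2 `COc1ccccc1Oc1cncc(C2=CC3CNCC(C2)C3)c1` gives 1 nM. The difference between the core of compound 1 and the core of compound 3 is not broken down here.

Compound 2 differs from compound 3 by methoxy in place of hydrogen on an aromatic carbon. This change produced a 1.4-fold higher number from compound 3 to compound 2 (0.15 log units; within the scatter).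

Compound 4 `COc1cc(C2=CC3CNCC(C2)C3)cnc1Cl` has not yet been measured. It differs from compound 1 by methoxy in place of hydrogen on an aromatic carbon. This is the same kind of change as that from compound 3 to compound 2, but the surroundings differ: in compound 2 the methoxy sits on an aromatic carbon of a six-membered aromatic ring of carbon only, ortho to a large group, whereas in compound 4 it sits on a six-membered aromatic ring with one nitrogen, ortho to a chloro group, two atoms from the ring nitrogen and meta to a group of 9 heavy atoms.

Going by the values given here, the only measured precedent for adding methoxy is the step from compound 3 to compound 2, which stayed within the scatter. On that basis, and resting on compound 1 at 0.4 nM, a step of about a 1.5-fold higher number from compound 1 to compound 4 (0.18 log units; within the scatter) is expected. For compound 4 the estimated value in this assay is 0.6 nM, with a likely range from 0.2 nM to 2 nM.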

Compound 4, inhibition constant: 0.4 nM
Beside the measured number, compound 4's estimate is 1.5-fold (0.18 log units) above it; low and high end bracket the measured number.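

In this assay, methoxy in place of hydrogen on an aromatic carbon gave no change at the digits printed from compound 1 to compound 4 (within the scatter), on a six-membered aromatic ring with one nitrogen, ortho to a chloro group and two atoms from the ring nitrogen. The two methoxy steps in this series cannot be told apart, so on this evidence the change carries from one core to the other without a detectable difference in size: the same change on two cores in this assay, a 1.4-fold higher number (0.15 log units; within the scatter) from compound 3 to compound 2 and no change at the digits printed (within the scatter) from compound 1 to compound 4, 1.4-fold (0.15 log units) apart, within the scatter of two such steps. This shows only that methoxy was tolerated at these two places on these two cores; it does not give a general rule for methoxy in the series, and, with the ring and surroundings differing as well as the core, it does not separate the contribution of the core from that of the place, nor does it exclude a small difference hidden within the scatter.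

The compounds shown leave open whether another group at the same place on compound 4, such as an amine, a carboxylic acid or a longer alkoxy chain, would also leave the number in this assay unmoved. Also open, as far as these compounds go, is how methoxy reads on that ring when the chloro group is replaced by hydrogen.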